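Efficacy of an amide series at the dopamine receptor

The compounds below may be only part of what the source reports. "The series", "measured", "known", "first", "only" and "open" are said of these compounds alone.

Compound 1 `Cc1cc(NC(=O)CN2CCC(c3cccc[n+]3[O-])CC2)ccc1F`: in a functional assay on HEK293 cells for agonist activity at D(4) dopamine receptor (Homo sapiens), read by FLIPR (a lower number here means a smaller maximal response, a higher number a larger maximal response), compound 1 gives 75%
Compound 2 `Cc1ccc(Cl)c(NC(=O)CN2CCC(c3cccc[n+]3[O-])CC2)c1Cl`: in this assay compound 2 gives 62%
Compound 3 `Cc1cccc(C(=O)NCN2CCC(c3cccc[n+]3[O-])CC2)c1`: in this assay compound 3 gives 77%

Among these three measurements compound 1 stands second highest. Its nearest neighbour is compound 3, whose value lies within the scatter of that of compound 1, so the two cannot be told apart. Compound 2 lies furthest away, with a value beyond the scatter below that of compound 1.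

Compound 4 `O=C(CN1CCC(c2cccc[n+]2[O-])CC1)Nc1ccccc1F` has not yet been measured. It differs from compound 1 in one place: 2-fluorophenyl in place of 4-fluoro-3-methylphenyl on an amide-type nitrogen. Within the data shown here, no measured pair in this set shows a step of this kind, so the size of the change in this assay is unknown from the data. The three measured values span only a modest range, and with the drop seen for compound 2 as the widest departure, a small downward step is expected, possibly within the scatter. For compound 4 the expected value in this assay is 68%, between 50% and 84%, corresponding to an estimated step of a number 7 percentage points lower from compound 1 to compound 4 (within the scatter).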

Compound 4, largest response reached (reported as efficacy), in percent of the reference or control that the assay uses: 63%
The estimate for compound 4 lay 5 percentage points above the measured number; measured number inside the range.
By their numbers in this assay, from the lowest: compounds 2 and 4 (each within the scatter of the next); then compounds 1 and 3 (each within the scatter of the next).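

Among these compounds, replacing 4-fluoro-3-methylphenyl with 2-fluorophenyl on the amide-type nitrogen gives the first readable step in this set: in this assay, the maximal response falls by a number 12 percentage points lower from compound 1 to compound 4 (beyond the scatter), a step that goes beyond the scatter. The maximal response therefore depends on the aryl group at this nitrogen, even though both groups carry a fluorine on a six-membered aromatic ring of carbon only. Nothing available explains this step.

This single step combines the loss of the methyl group with a change in where the fluorine sits, and the compounds shown do not separate the two. Going by these compounds, it also remains open how an unsubstituted phenyl or a 2-chlorophenyl on the same nitrogen would compare with compound 1 in this assay.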